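A few compounds are considered here, and "the series" means these few. Any claim that something is new, unique, unknown or untested is made for them only; others in the source may bear on it.

Measured compounds:
compound 1, `Cc1cc(=O)c2c(O)c(CN3CCCC3C(=O)O)c(O)c([C@H]3CCN(C)C[C@H]3O)c2o1`, with 21%
compound 2, `Cc1oc2c([C@H]3CCN(C)C[C@H]3O)c(O)cc(O)c2c(=O)c1C(O)c1ccc([N+](=O)[O-])cc1`, with 4%

In a functional assay on MCF7 cells (Homo sapiens) for inhibition, read by MTT assay, with a stated time of 48 h, tested at 10 uM (a lower number here means less inhibition of growth, a higher number more inhibition of growth at the concentration tested), compound 1 gives 21%, while compound 2 gives 4%. Compound 2 thus stands lowest of the two numbers measured; its nearest neighbour is compound 1, whose number lies higher by a gap beyond the usual scatter. Among the compounds with values here, only these two values are known, and no single-point step between measured compounds is available, so the two values alone describe where compound 2 stands.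

Compound 3, `Cc1oc2c([C@H]3CCN(C)C[C@H]3O)c(O)cc(O)c2c(=O)c1C(O)c1csc([N+](=O)[O-])c1`, is not yet measured. It differs from compound 2 in one place: 5-nitrothiophen-3-yl in place of 4-nitrophenyl on a saturated chain carbon bound to an aromatic carbon and an oxygen on a saturated carbon. The groups that leave and enter are close in size and kind, so no large movement is expected. Compound 3 is expected to show a step of a number 3 percentage points higher from compound 2 to compound 3 (within the scatter) that stays within the scatter. The estimate for compound 3 in this assay is 7%, with a range from 0% to 20%.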

Compound 3, percent growth inhibition at one concentration: 20%
The estimate for compound 3 lay 13 percentage points below the measured number, within the range that was stated.
By their numbers in this assay, from the lowest: compound 2; then compounds 3 and 1 (each within the scatter of the next).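

In this assay, within the data shown here, placing 5-nitrothiophen-3-yl in place of 4-nitrophenyl on a saturated chain carbon bound to an aromatic carbon and an oxygen on a saturated carbon gives a number 16 percentage points higher from compound 2 to compound 3 (beyond the scatter), the only single-place step available so far. It shows that this position is not indifferent to the ring it carries: exchanging a six-membered aromatic ring of carbon only for a five-membered aromatic ring with sulfur as its hetero atom, with a nitro group on both, is enough to shift growth inhibition at the concentration tested. Nothing available explains why this exchange shifts the read-out.

The compounds shown leave open whether the shift belongs to the thiophene ring itself or to where the nitro group sits on it, since a single pair cannot separate the two. They also leave open how an amine or a carboxylic acid in place of the nitro group would behave on either ring, and whether a ketone in place of the hydroxyl on the chain carbon would preserve the step.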